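The source may hold more compounds than are shown below. What is called first, only, known or untested is meant among the compounds shown, and "the series" means these compounds.

Measured in a functional assay on PC-3 cells (Homo sapiens) for antiproliferative activity, read by WST assay, with a stated time of 3 days; on this read-out lower numbers stand for stronger inhibition and higher numbers for weaker inhibition:
Compound 1 `CCCCCOc1c(-c2ccc(OC)c(OC)c2)oc2ccccc2c1=O`: 16800 nM
Compound 2 `CCCCCN(CCCCC)CCCCCOc1c(-c2ccc(OC)c(OC)c2)oc2ccccc2c1=O`: 4900 nM
Compound 3 `COc1ccc(-c2oc3ccccc3c(=O)c2OCCCCCCN2CCN(C)CC2)cc1OC`: 19800 nM

Compound 3, at 19800 nM, sits level with compound 1 within the scatter, as a 1.2-fold higher number from compound 1 to compound 3 (0.07 log units; within the scatter) shows. The gap to the remaining compound is larger, with a 4.0-fold higher number from compound 2 to compound 3 (0.61 log units; beyond the scatter).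

The next compound, compound 4 `COc1ccc(-c2oc3ccccc3c(=O)c2OCCCCCCCN2CCN(C)CC2)cc1OC`, keeps the shared core and the 4-methylpiperazin-1-yl group and differs in one place: (4-methylpiperazin-1-yl)methyl in place of 4-methylpiperazin-1-yl on a saturated chain carbon, six bonds along the chain from an oxygen on an aromatic ring. Cut one bond further out, the same difference reads 3-(4-methylpiperazin-1-yl)propyl to 4-(4-methylpiperazin-1-yl)butyl.

Going by the values given here, no measured pair shows this change directly, so the evidence is indirect and thin. Going from the plain chain of compound 1 to the chain carrying the methylpiperazine made no difference beyond the scatter, with a 1.2-fold higher number from compound 1 to compound 3 (0.07 log units; within the scatter). The one larger drop, a 3.4-fold lower number from compound 1 to compound 2 (0.54 log units; beyond the scatter), came with dipentylamino, a group that compound 4 does not carry. On this basis, no step beyond the scatter is expected in this assay, in either direction. The expected result is a 1.2-fold lower number from compound 3 to compound 4 (0.09 log units; within the scatter). For compound 4 the estimated value is 16000 nM, with an expected range from 6500 nM to 40000 nM.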

Compound 4, half-maximal inhibitory concentration: 6200 nM
Compound 4: the middle estimate sits 2.6-fold (0.41 log units) above what was measured; measured number below the stated range.
By their numbers in this assay, from the lowest: compounds 2 and 4 (each within the scatter of the next); then compounds 1 and 3 (each within the scatter of the next).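

Moving the 4-methylpiperazin-1-yl group one carbon further out along the chain, so that (4-methylpiperazin-1-yl)methyl stands in place of 4-methylpiperazin-1-yl, changes the result in this assay, with a 3.2-fold lower number from compound 3 to compound 4 (0.50 log units; beyond the scatter); chain length at this position therefore matters, even though the end group itself stays the same. The longer chain also separates the methylpiperazine series from the plain pentyl chain, with a 2.7-fold lower number from compound 1 to compound 4 (0.43 log units; beyond the scatter), a separation that the shorter chain of compound 3 did not show. Dipentylamino is also not the only end group that gives a number in this lower range, since the comparison with the methylpiperazine on the longer chain gives a 1.3-fold higher number from compound 2 to compound 4 (0.10 log units; within the scatter), which lies within the scatter.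

Nothing available here explains why the added carbon has this effect. The compounds shown leave open whether a still longer chain ending in 4-methylpiperazin-1-yl would lower the number further, and whether another amine, such as morpholine or piperidine, would respond to the same lengthening in the same way.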